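The source may report more compounds than this note shows. Statements on the series, on what has been measured and on what is new or still open speak of the compounds shown alone.

In a functional assay on A549 cells (Homo sapiens) for inhibition, read by MTT assay, with a stated time of 72 h (on this read-out lower numbers stand for stronger inhibition and higher numbers for weaker inhibition), compound 1 (`CC(C)(C)n1cc2c(n1)C(=O)CC1(CCN(C(=O)c3cc(-c4ccc(Cl)cc4)nc4ccccc34)CC1)O2`) gives 2330 nM. Within the data shown here, compound 2 (`CC(C)(C)n1cc2c(n1)C(=O)CC1(CCN(C(=O)c3cc(-c4ccncc4)nc4ccccc34)CC1)O2`) gives 550 nM, the lower of the two numbers so far. Among the measured compounds shown here, the one measured step, a 4.2-fold lower number from compound 1 to compound 2 (0.63 log units; beyond the scatter), is pyridin-4-yl in place of 4-chlorophenyl on an aromatic carbon.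

Next in line is compound 3 (`CC(C)Oc1cc(C(=O)N2CCC3(CC2)CC(=O)c2nn(C(C)(C)C)cc2O3)c2ccccc2n1`), with isopropoxy in place of pyridin-4-yl on an aromatic carbon. The change falls on the same aromatic carbon as the measured step, next to the ring nitrogen.

For the measured compounds named here, only that step bears on the change, and it is modest, though beyond the scatter. Going by the values given here, it swaps one ring group for another, whereas isopropoxy has no ring, and no compound without a ring at this place has been measured. A step of similar modest size is therefore expected in this assay, more likely towards a higher number given that compound 2 is the lowest so far, but the direction is poorly supported. The expected change is a 2.0-fold higher number from compound 2 to compound 3 (0.30 log units; within the scatter). For compound 3 the estimated value is 1100 nM, with an expected range of 350 nM to 3500 nM.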

Compound 3, half-maximal inhibitory concentration: > 10000 nM
Compound 3 ended at the assay's limit; the forecaster's own chance of this, stated with the estimate: 5%; middle value at least 9.0-fold (0.95 log units) away from the limit.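

The aromatic carbon next to the ring nitrogen proves far more sensitive to the choice of group than the earlier pair could show: isopropoxy in place of pyridin-4-yl gives an at least 18-fold higher number from compound 2 to compound 3 (1.25 log units; beyond the scatter), a large step in this assay. Isopropoxy in place of 4-chlorophenyl gives an at least 4.2-fold higher number from compound 1 to compound 3 (0.63 log units; beyond the scatter), so among the compounds shown, both groups carrying a six-membered aromatic ring give lower numbers than isopropoxy, which has no ring, and none of the three goes against this. For compound 3 the reading in this assay is a limit of the assay and not a number, so both steps to it give only a minimum size: the limit of > 10000 nM in this assay, at which 1 of the 3 values shown sits.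

The change from either ring group to isopropoxy removes the ring, lowers the heavy-atom count and attaches the group through oxygen all at once, so these compounds cannot separate the three changes. A cyclopropyl ring, a phenoxy group or an amine such as dimethylamino at this carbon would bear on which of them matters, while the steepness of the fall between the ring groups and isopropoxy remains unsettled.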